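Replacing isobutoxy with 4-aminophenyl on compound 3

The source may hold more compounds than are shown below. What is called first, only, known or untested is meant among the compounds shown, and "the series" means these compounds.

Measured in a functional assay on HCT-116 cells (Homo sapiens) for cytotoxicity, read by MTT assay; on this read-out higher numbers stand for weaker inhibition and lower numbers for stronger inhibition:
compound 1 `CCc1cc(S(=O)(=O)N2C[C@H](c3ccccc3)NC2=O)ccc1NC(=O)c1ccc([N+](=O)[O-])cc1`, 500 nM
compound 2 `CCc1cc(S(=O)(=O)N2C[C@H](c3ccccc3)NC2=O)ccc1NC(=O)NC1CCCCC1`, 300 nM
compound 3 `CCc1cc(S(=O)(=O)N2C[C@H](c3ccccc3)NC2=O)ccc1NC(=O)OCC(C)C`, 60 nM

Compound 3 holds the lowest of the three numbers in this assay; the gaps to its neighbours read a 5.0-fold lower number from compound 2 to compound 3 (0.70 log units; beyond the scatter) and an 8.3-fold lower number from compound 1 to compound 3 (0.92 log units; beyond the scatter), both beyond the scatter. Compound 4 `CCc1cc(S(=O)(=O)N2C[C@H](c3ccccc3)NC2=O)ccc1NC(=O)c1ccc(N)cc1` differs from compound 3 by 4-aminophenyl in place of isobutoxy on a carbonyl carbon. The step that bears most on this is an 8.3-fold lower number from compound 1 to compound 3 (0.92 log units; beyond the scatter), which exchanged 4-nitrophenyl for isobutoxy on the same carbonyl carbon; compound 4 reverses that exchange, with amino in place of nitro on the phenyl. Among the compounds with values here, compound 4 is therefore expected to show a modest rise, a 6.7-fold higher number from compound 3 to compound 4 (0.82 log units; beyond the scatter), since no measured compound shows a 4-aminophenyl there. Compound 4 is estimated at 400 nM, within 120 nM to 1500 nM.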

Compound 4, half-maximal inhibitory concentration: 460 nM
Compound 4: the middle estimate sits 1.2-fold (0.06 log units) below what was measured; the range from low to high includes it.
By their numbers in this assay, from the lowest: compound 3; then compounds 2, 4 and 1 (each within the scatter of the next).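

In this assay, swapping nitro for amino on the aromatic carbon leaves the number unchanged within the scatter, a 1.1-fold lower number from compound 1 to compound 4 (0.04 log units; within the scatter), and compound 4 also stays level with the cyclohexylamino compound, a 1.5-fold higher number from compound 2 to compound 4 (0.19 log units; within the scatter). Among these four compounds only isobutoxy stands apart on this carbonyl carbon, a 7.7-fold higher number from compound 3 to compound 4 (0.88 log units; beyond the scatter), and the substituent on the phenyl ring does not close that gap in this pair. No measurement given here explains this difference. From the compounds shown here alone, whether the lower number follows the oxygen of isobutoxy or its branched chain remains open; a methoxy, n-butoxy or isobutyl group on the same carbonyl carbon would help separate the two.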